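Series notes: from compound 2 to compound 3

The source may report more compounds than this note shows. Statements on the series, on what has been measured and on what is new or still open speak of the compounds shown alone.

Measured so far in a physicochemical assay for solubility, in phosphate buffer, at pH 6.5; a higher number here means a more soluble compound, a lower number a less soluble compound
- compound 1 `CN(C)Cc1ccc(NC(=O)Nc2cccnc2Oc2ccccc2C(C)(C)C)c(F)c1` gives 160 ug/mL
- compound 2 `CN(C)Cc1cccc(-c2ccc(NC(=O)Nc3cccnc3Oc3ccccc3C(C)(C)C)c(F)c2)c1` gives 17 ug/mL

Compound 2 stands lower of the two measured compounds, with 17 ug/mL in this assay against the higher number of compound 1.

The next compound is compound 3 `CC(C)N1CCC(COc2ccc(NC(=O)Nc3cccnc3Oc3ccccc3C(C)(C)C)c(F)c2)CC1` and it carries (1-isopropylpiperidin-4-yl)methoxy in place of 3-((dimethylamino)methyl)phenyl on an aromatic carbon with the rest of the structure unchanged.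

Within the data shown here, only one measured step bears on this change. It is a 9.4-fold lower number from compound 1 to compound 2 (0.97 log units; beyond the scatter) and it is the step in which 3-((dimethylamino)methyl)phenyl came in place of (dimethylamino)methyl. That modest step lies beyond the scatter. Among the measured compounds shown here, compound 3 loses this same group, so part of that step is expected to be recovered, but no measured compound carries the entering group, and a full return is not assumed. The expected change in this assay is therefore upward, estimated as a 4.1-fold higher number from compound 2 to compound 3 (0.61 log units; beyond the scatter) and beyond the scatter. The estimate for compound 3 is 70 ug/mL within an expected range of 20 ug/mL to 220 ug/mL on current evidence.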

Compound 3, solubility: 232 ug/mL
Estimate against measurement, compound 3: 3.3-fold (0.52 log units) below, outside the stated range (above it).
By their numbers in this assay, from the lowest: compound 2; then compounds 1 and 3 (each within the scatter of the next).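

In this assay, the change at this aromatic carbon, meta to a fluoro group, gives a 14-fold higher number from compound 2 to compound 3 (1.14 log units; beyond the scatter) when (1-isopropylpiperidin-4-yl)methoxy replaces 3-((dimethylamino)methyl)phenyl, so the low number of compound 2 does not follow from every large group placed here. The comparison with the smaller (dimethylamino)methyl group gives a 1.5-fold higher number from compound 1 to compound 3 (0.16 log units; within the scatter) and places compound 1 and compound 3 level in this assay, which means that this larger group, unlike the 3-((dimethylamino)methyl)phenyl group, comes with no loss beyond the scatter. Nothing available accounts for the difference between the two large groups.

The entering group differs from the group it replaces in its ring, its oxygen link and its nitrogen substitution all at once, so the compounds shown leave open which of these features goes with the step. Also open, on these data alone, is whether a 3-((dimethylamino)methyl)phenoxy group, a piperidine with a free ring amine, or a morpholine on the same methoxy link would hold the number of compound 3 or return towards that of compound 2.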